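This account rests on a few compounds, and the source may have more. Where it says the series, first, only, none or still open, it means among the compounds named here.

Of the compounds shown here, two have been measured in a functional assay on a cell-free system (plasma, Oryctolagus cuniculus) for inhibition, with stated times of 5 min, 1 min and 6 min; a lower number here means a stronger inhibitor, a higher number a weaker inhibitor. Compound 1, `CCOC(=O)c1c(C)nc(-c2ccc(OCC(C)C)c(C#N)c2)n1O`, gives 16800 nM. Compound 2, `CCOC(=O)c1c(C)nc(-c2cccc(C#N)c2)n1OCc1ccncc1`, gives 6200 nM. Of these two numbers compound 2 has the lower one, and the gap to compound 1 is wider than the ordinary scatter of repeated measurements, so compound 2 is the stronger inhibitor of the pair.

Compound 3, `CCOC(=O)c1c(C)nc(-c2cccc(C#N)c2)n1OCc1ccc(C)cc1`, has not yet been measured. It differs from compound 2 in a single place: 4-methylphenyl in place of pyridin-4-yl on a saturated chain carbon bound to an oxygen on an aromatic ring. For the measured compounds named here, no measured pair in this set shows this kind of exchange, so its effect is unknown here and can only be guessed.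

The step from compound 2 to compound 3 is expected to be small, within the scatter, with no clear direction: a 1.2-fold lower number from compound 2 to compound 3 (0.09 log units; within the scatter). On that basis compound 3 is expected to give about 5000 nM in this assay, within a range from 1500 nM to 16000 nM.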

Compound 3, half-maximal inhibitory concentration: 6310 nM
Estimate against measurement, compound 3: 1.3-fold (0.10 log units) below; measured number inside the range.
By their numbers in this assay, from the lowest: compounds 2 and 3 (each within the scatter of the next); then compound 1.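

In this assay, putting 4-methylphenyl in place of pyridin-4-yl on a saturated chain carbon bound to an oxygen on an aromatic ring gives a 1.0-fold higher number from compound 2 to compound 3 (0.01 log units; within the scatter) and so leaves the two compounds indistinguishable. This exchange removes the ring nitrogen, the one hydrogen-bond acceptor counted in the leaving group, and adds a methyl group, yet no difference can be read in this assay for this pair of compounds. No separate measurement bears on this result, so the flat step stands without an explanation.

From the compounds shown here alone, whether an aliphatic amine or a carboxylic acid on this ring, or a longer chain between the ring and the oxygen, would move the number remains open. Going by these compounds, compound 1 differs from compound 2 and compound 3 in more than one place, so the separate contribution of each of those differences also remains unknown.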